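The source may report more compounds than this note shows. Statements on the series, on what has been measured and on what is new or still open speak of the compounds shown alone.

Compound 1 `CCC(C)(C)Cc1c[nH]c(CCc2ccc(-c3cccc(C)n3)cc2)n1` stands lowest of the three numbers in an in vitro assay on CHO cells for displacement of a labelled ligand from Bombesin receptor subtype-3 (Homo sapiens), read by scintillation counting, with a stated time of 2 h; a lower number here means a stronger inhibitor, a higher number a weaker inhibitor: compound 1 gives 6.3 nM. Compound 2 `CCC(C)(C)Cc1c[nH]c(CCc2ccc(-c3ccncc3)cc2)n1` gives 101 nM, and compound 3 `CCC(C)(C)Cc1c[nH]c(CCc2ccc(-n3cccn3)cc2)n1` gives 33 nM. The unmeasured compound 4 `CCC(C)(C)Cc1c[nH]c(CCc2ccc(-c3cccnc3C(=O)O)cc2)n1` differs from compound 1 in one place: 2-carboxypyridin-3-yl in place of 6-methylpyridin-2-yl on an aromatic carbon. Among the measured compounds shown here, two measured steps bear on this change, since each also replaces the 6-methylpyridin-2-yl on that aromatic carbon: a 16-fold higher number from compound 1 to compound 2 (1.20 log units; beyond the scatter) and a 5.2-fold higher number from compound 1 to compound 3 (0.72 log units; beyond the scatter). For the measured compounds named here, both raised the number beyond the scatter, so a higher number is expected for compound 4 in this assay, though the 2-carboxypyridin-3-yl has no measured counterpart here. The step is estimated as a 16-fold higher number from compound 1 to compound 4 (1.20 log units; beyond the scatter). Compound 4 is therefore expected to give about 100 nM, within a range of 20 nM to 600 nM.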

Compound 4, half-maximal inhibitory concentration: 560 nM
Compound 4: middle estimate off by 5.6-fold (0.75 log units), on the low side, within the range that was stated.
By their numbers in this assay, from the lowest: compound 1; then compound 3; then compound 2; then compound 4.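

In this assay, the 2-carboxypyridin-3-yl gives the largest rise yet at this place on the carbon-only aromatic ring, with an 89-fold higher number from compound 1 to compound 4 (1.95 log units; beyond the scatter). It also stands above both earlier replacements, with a 17-fold higher number from compound 3 to compound 4 (1.23 log units; beyond the scatter) and a 5.5-fold higher number from compound 2 to compound 4 (0.74 log units; beyond the scatter), so the span of numbers across groups at this position is wider than the first three compounds showed. No evidence is available that accounts for the size of this rise.

As far as these compounds go, it remains open whether a plain pyridin-3-yl, a methyl ester or a primary amide in place of the 2-carboxypyridin-3-yl's carboxylic acid would bring the number back toward that of compound 1.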